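The source may report more compounds than this note shows. Statements on the series, on what has been measured and on what is new or still open speak of the compounds shown alone.

Measured so far in a functional assay on SK-BR-3 cells (Homo sapiens) for antiproliferative activity, read by MTT assay, with a stated time of 72 h; a lower number here means a stronger inhibitor, a higher number a weaker inhibitor:
Compound 1 `C/C=C1/[C@H](O[C@@H]2O[C@H](COC(C)=O)[C@@H](OC(C)=O)[C@H](OC(C)=O)[C@H]2OC(C)=O)OC=C(C(=O)OC)[C@H]1CC(=O)OCCC`: 6600 nM.
Compound 2 `C#CCOC(=O)C[C@@H]1C(C(=O)OC)=CO[C@@H](O[C@@H]2O[C@H](CO)[C@@H](O)[C@H](O)[C@H]2O)/C1=C/C`: > 15000 nM, a limit of the assay rather than a number.
Compound 3 `C=C(C)CCOC(=O)C[C@@H]1C(C(=O)OC)=CO[C@@H](O[C@@H]2O[C@H](CO)[C@@H](O)[C@H](O)[C@H]2O)/C1=C/C`: > 15000 nM, likewise a limit rather than a number.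

Compound 3 therefore stands at the limit of this assay, as does compound 2; only compound 1 gives a number. For the measured compounds named here, the single one-point step recorded, a step that the two limits leave unreadable from compound 2 to compound 3, cannot be read in size, since both of its ends are limits. the limit of > 15000 nM in this assay, at which 2 of the 3 values shown sit, is the whole of what is known on the side of compound 3.

Compound 4 `C/C=C1/[C@H](O[C@@H]2O[C@H](CO)[C@@H](O)[C@H](O)[C@H]2O)OC=C(C(=O)OC)[C@H]1CC(=O)OCCC1CCCCC1` differs from compound 3 by cyclohexyl in place of 1-methylethenyl on a saturated chain carbon, two bonds along the chain from an oxygen next to a carbonyl group. Going by the values given here, no measured step bears directly on this change: the only step between measured neighbours, from compound 2 to compound 3, has no readable size. Compound 1 alone gives a number, but it differs from compound 3 in more than one place, so it offers no one-point comparison. The expectation for compound 4 is accordingly weak: nothing in the series indicates a step beyond the scatter, and a step that the limit leaves unreadable from compound 3 to compound 4 is expected, most probably ending once more at the limit. Compound 4 is estimated at 20000 nM, in a range from 8000 nM to 60000 nM.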

Compound 4, half-maximal inhibitory concentration: 2000 nM
The estimate for compound 4 lay 10-fold (1.00 log units) above the measured number; the whole stated range lies above it.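

In this assay, the chain on the saturated carbon, two bonds along from an oxygen next to a carbonyl group, now gives its first one-place change of readable size: cyclohexyl in place of 1-methylethenyl gives an at least 7.5-fold lower number from compound 3 to compound 4 (0.87 log units; beyond the scatter). The same difference, read one bond closer to that oxygen as cyclohexylmethyl in place of ethynyl on a saturated chain carbon, gives an at least 7.5-fold lower number from compound 2 to compound 4 (0.87 log units; beyond the scatter), so this position tolerates a large carbocyclic group and compound 4 moves clear of the limit. Both steps are bounds rather than exact sizes, and the step between the two compounds at the limit cannot be read, leaving the full size of the change and the order of the two unsaturated chains unknown: the limit of > 15000 nM in this assay, at which 2 of the 4 values shown sit.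

On these data alone, it remains open whether the ring itself or simply the larger carbon group goes with the lower number; a straight hexyl chain or a phenyl ring in place of cyclohexyl would separate these. As far as these compounds go, it is also open how the step would read with the acetyl groups of compound 1 present alongside the 2-cyclohexylethyl chain.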